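Propanoyl to isopropylcarbonyl in the shared core

The source may report more compounds than this note shows. Statements on the series, on what has been measured and on what is new or still open speak of the compounds shown alone.

Measured so far in an assay on HEK293 cells for positive allosteric modulation of metabotropic glutamate receptor 3 (Rattus norvegicus), read by thallium flux, with a stated time of 2.5 min; on this read-out higher numbers stand for an effect only at larger amounts of compound and lower numbers for an effect already at smaller amounts:
Compound 1 `CCCC(=O)c1ccc(OCCCCOc2ccc(F)c(C(=O)O)c2)c(C)c1O` gives 438 nM.
Compound 2 `Cc1c(OCCCCOc2ccc(F)c(C(=O)O)c2)ccc(C(=O)CC(C)(C)C)c1O` gives 258 nM.
Compound 3 `CCC(=O)c1ccc(OCCCCOc2ccc(F)c(C(=O)O)c2)c(C)c1O` gives "not determined" (no result reported).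

Among the measured compounds shown here, compound 3 thus stands without a number in this assay; its two neighbours, compound 1 and compound 2, both carry values within the scatter of each other, and the one step that joins them, a 1.7-fold lower number from compound 1 to compound 2 (0.23 log units; within the scatter), is the only measured change at the saturated chain carbon bound to the carbonyl carbon. Compound 4 `Cc1c(OCCCCOc2ccc(F)c(C(=O)O)c2)ccc(C(=O)C(C)C)c1O` differs from compound 3 by methyl in place of hydrogen on a saturated chain carbon bound to a carbonyl carbon and a saturated chain carbon, a smaller enlargement of the same chain than the measured step. With that step within the scatter, no shift beyond the scatter is expected for compound 4 in this assay. Compound 4 is therefore estimated at 350 nM, in the range 120 nM to 1000 nM.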

Compound 4, half-maximal effective concentration: > 10000 nM
Compound 4: a limit, no number; the forecaster's own chance of this, stated with the estimate: 10%; middle value at least 28-fold (1.45 log units) away from the limit.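

The result for compound 4 is a limit, not a number: the limit of > 10000 nM in this assay, at which 1 of the 4 values shown sits. Isopropyl on the carbonyl carbon gives an at least 22-fold higher number from compound 1 to compound 4 (1.35 log units; beyond the scatter) in place of propyl, and an at least 38-fold higher number from compound 2 to compound 4 (1.58 log units; beyond the scatter) in place of neopentyl. This position therefore tolerates a change of chain far less evenly than the earlier step suggested, a 1.7-fold lower number from compound 1 to compound 2 (0.23 log units; within the scatter).

Compound 3 carries no number, so the step to compound 4 cannot be read. From the compounds shown here alone, whether a cyclopropyl or a tert-butyl directly on the carbonyl carbon behaves like isopropyl remains open.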